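Swapping the Ester Chain on a Coumarin Migration Inhibitor

A few compounds are considered here, and "the series" means these few. Any claim that something is new, unique, unknown or untested is made for them only; others in the source may bear on it.

Measured so far:
compound 1 `CC(=O)OCc1ccc2oc(=O)c(C(=O)Oc3cccc(Cl)c3)cc2c1`, 95.2%
compound 2 `CC(=O)OCc1ccc2oc(=O)c(C(=O)Sc3ccccc3)cc2c1`, 89.5%
compound 3 `CCCCCC(=O)OCc1ccc2oc(=O)c(C(=O)Oc3cccc(Br)c3)cc2c1`, 94.3%

The read-out throughout is a functional assay on HT-1080 cells (Homo sapiens), read by transwell migration, with a stated time of 24 h, tested at 0.1 uM; a lower number here means a stronger effect, a higher number a weaker effect of the compound at the concentration tested. Compound 3 gives 94.3%, the second highest of the three numbers; compound 1 gives a value that is higher by less than the scatter, and compound 2 a value lower by less than the scatter, so all three stand together.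

Compound 4 `CC(C)(C)C(=O)OCc1ccc2oc(=O)c(C(=O)Oc3cccc(Br)c3)cc2c1` differs from compound 3 in one place: tert-butyl in place of pentyl on a carbonyl carbon. Going by the values given here, no measured pair shows this change. Among the compounds with values here, the only single-place step available is a number 5.7 percentage points lower from compound 1 to compound 2 (within the scatter), which touches the other end of the shared core and stayed within the scatter. Within the data shown here, compounds 1 and 3 differ in two places and their values are within the scatter of each other, which says only that a change at the chain end has not so far moved the number.

With nothing pointing to a shift, compound 4 is expected to give about 93%, in the range 80% to 102%. The step of a number 1.3 percentage points lower from compound 3 to compound 4 (within the scatter) is thus expected to be no larger than the scatter.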

Compound 4, a percentage reported as activity, at one concentration (the size of the read-out at that concentration, not a potency): 65.2%
The estimate for compound 4 lay 27.8 percentage points above the measured number, and the stated range ends above it.
By their numbers in this assay, from the lowest: compound 4; then compounds 2, 3 and 1 (each within the scatter of the next).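

The position at the far end of the ester chain can clearly affect this read-out: in this assay, tert-butyl in place of pentyl on a carbonyl carbon gives a number 29.1 percentage points lower from compound 3 to compound 4 (beyond the scatter), the only step among these compounds that lies beyond the scatter. Compound 3 and compound 4 differ in this one place, and both groups are made of carbon only, with no ring, no hydrogen-bond donors or acceptors and no net charge, so the drop appears with none of those counts changing. No measurement shown here bears on why the number moved.

Going by these compounds, this single pair cannot separate the effect of branching from the effect of losing a carbon from the chain, and how a straight butyl chain, an isopropyl group or an amine-bearing chain at the same place would read remains open. Going by these compounds alone, it is also open whether tert-butyl moves the number in the same way when the other end of the molecule is the one found in compound 1 or compound 2.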